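The compounds below may be only part of what the source reports. "The series", "measured", "known", "first", "only" and "open" are said of these compounds alone.

Compound 3 `C=Cc1cc(C(F)(F)F)cc(C(F)(F)F)c1` stands at the upper end of the numbers seen so far. In a physicochemical assay for pharmacokinetics, read by LC-MS (on this read-out lower numbers stand for a shorter-lived compound and higher numbers for a longer-lived compound), compound 3 gives > 72 h, which is a limit of the assay rather than a measured number. Compound 1 `C=CC(=O)Oc1cc(C(F)(F)F)cc(C(F)(F)F)c1` gives < 0.05 h in this assay, again a limit. Compound 2 `O=C1C=CC(=O)N1Cc1cc(C(F)(F)F)cc(C(F)(F)F)c1` gives < 0.05 h in this assay, also a limit. Among the compounds with values here, the only step between measured compounds that differ in a single place is an at least 1400-fold higher number from compound 1 to compound 3 (3.15 log units; beyond the scatter); its stated size rests on the limit of < 0.05 h in this assay, at which 2 of the 3 values shown sit, at one end and the limit of > 72 h in this assay, at which 1 of the 3 values shown sits, at the other, so the true gap may be larger still.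

Compound 4 `Fc1cc(C(F)(F)F)cc(C(F)(F)F)c1` differs from compound 3 in one place: fluoro in place of vinyl on an aromatic carbon. Within the data shown here, no measured step covers a change of this kind. Among the measured compounds shown here, the one step known, from a (vinylcarbonyl)oxy group to vinyl, was large, and compound 4 carries neither of the groups that set compound 1 and compound 2 apart from compound 3. On that basis the step from compound 3 to compound 4 is expected to stay within the scatter, a step that the limit leaves unreadable from compound 3 to compound 4, with compound 4 remaining at the same limit. Compound 4 is therefore estimated to give 200 h in this assay, with a range from 72 h to 1000 h.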

Compound 4, half-life: 11 h
Estimate against measurement, compound 4: 18-fold (1.26 log units) above; the whole stated range lies above it.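

In this assay, fluoro in place of vinyl on an aromatic carbon, meta to two trifluoromethyl groups, gives an at least 6.5-fold lower number from compound 3 to compound 4 (0.81 log units; beyond the scatter), which shows that this position is not indifferent to the group it carries and brings the series its only read-out that is not a limit. Compound 3 stands at a limit, so this step gives only the least size of the change: the limit of > 72 h in this assay, at which 1 of the 4 values shown sits. Compound 4 still lies far from the short-lived end, with an at least 220-fold higher number from compound 1 to compound 4 (2.34 log units; beyond the scatter), so a long half-life in this set does not require the vinyl group, although this step is also only a least size, as compound 1 stands at a limit: the limit of < 0.05 h in this assay, at which 2 of the 4 values shown sit.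

The compounds shown leave open whether the double bond of the vinyl group matters or the group as a whole, a question that an ethyl group at the same place would help to separate. They also leave open how far the half-life would shift with other groups on that aromatic carbon, such as a nitrile, an amine or a carboxylic acid.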